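Replacing a sulfur-bearing side chain with dimethylcarbamoyl

The compounds below may be only part of what the source reports. "The series", "measured", "known", "first", "only" and "open" are said of these compounds alone.

Compound 1 `COC/C1=C/C[C@](C)(CCC=C(C)C)/C=C/[C@@H](OC(=O)C=C(C)C)[C@](C)(O)/C=C/C1=O` gives 3950 nM
Compound 2 `CSC(=S)OC/C1=C/C[C@](C)(CCC=C(C)C)/C=C/[C@@H](OC(=O)C=C(C)C)[C@](C)(O)/C=C/C1=O` gives 380 nM

For the measured compounds named here, in a functional assay on A549 cells (Homo sapiens) for antiproliferative activity, read by MTT assay, with a stated time of 48 h (a lower number here means a stronger inhibitor, a higher number a weaker inhibitor), compound 2 gives 380 nM as the lower of the two numbers so far, and so stands as the stronger inhibitor of the pair.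

Compound 3 `CC(C)=CCC[C@]1(C)/C=C/[C@@H](OC(=O)C=C(C)C)[C@](C)(O)/C=C/C(=O)/C(C(=O)N(C)C)=C\C1` has not yet been measured. It differs from compound 2 on a double-bonded ring carbon: a group of 5 heavy atoms (3 carbon, 1 nitrogen, 1 oxygen; no ring) in place of a group of 6 heavy atoms (3 carbon, 1 oxygen, 2 sulfur; no ring), on a double-bonded ring carbon with dimethylcarbamoyl as the group that enters. The group that leaves holds both sulfur atoms, and dimethylcarbamoyl holds none.

Going by the values given here, only one measured step bears on this change, and it is a large one: a 10-fold lower number from compound 1 to compound 2 (1.02 log units; beyond the scatter) when the sulfur-bearing end was introduced on the same side chain. Compound 3 gives that end up, so a higher number is expected in this assay and much of that step may be reversed. Among the compounds with values here, no measured compound carries dimethylcarbamoyl, so the range stays wide.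

The expected change is a 4.7-fold higher number from compound 2 to compound 3 (0.68 log units; beyond the scatter) as an estimate. Compound 3 is expected at 1800 nM (estimated range 450 nM to 7000 nM).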

Compound 3, half-maximal inhibitory concentration: 2700 nM
The estimate for compound 3 lay 1.5-fold (0.18 log units) below the measured number; the range from low to high includes it.
By their numbers in this assay, from the lowest: compound 2; then compounds 3 and 1 (each within the scatter of the next).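

In this assay the exchange of the sulfur-bearing side chain for dimethylcarbamoyl on the double-bonded ring carbon reads as a 7.1-fold higher number from compound 2 to compound 3 (0.85 log units; beyond the scatter) and so shows that this amide group does not keep the gain seen with that side chain. The comparison with methoxymethyl at the same place gives a 1.5-fold lower number from compound 1 to compound 3 (0.17 log units; within the scatter) and places compound 1 and compound 3 level, so among these three compounds only the group holding both sulfur atoms stands apart, even though dimethylcarbamoyl and methoxymethyl are different groups. No measurement at hand explains why the sulfur-bearing side chain stands apart.

Open, on these data alone, is whether the sulfur atoms themselves matter or the whole side chain does, as the group that leaves differs from dimethylcarbamoyl in more than its sulfur atoms. A matching side chain with oxygen in place of its doubly bonded sulfur, or a carboxylic acid or a hydroxymethyl group on the same ring carbon, would show how far this position tolerates other groups.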